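Baylor-type diaminopyrimidine series: para bromo in place of chain

A few compounds are considered here, and "the series" means these few. Any claim that something is new, unique, unknown or untested is made for them only; others in the source may bear on it.

Measured compounds:
compound 1 `Nc1ncc(Cc2cc(CO)cc(CO)c2)c(N)n1` — 2.49
compound 2 `COCc1cccc(Cc2cnc(N)nc2N)c1` — 3.65
compound 3 `COCCOc1ccc(Cc2cnc(N)nc2N)cc1` — 3.08

The three measured compounds share one core and differ only in what sits on the benzylic ring. In a functional assay on L5178Y cells (Mus musculus) for inhibition (a lower number here means a less potent compound, a higher number a more potent compound, by a factor of ten per unit of this negative logarithm), compound 2 gives 3.65, the highest number of the three. Compound 3 stands second of three: its value in this assay sits below compound 2 by a gap that is beyond the usual scatter, and above compound 1, which gives 2.49, again by a gap beyond the scatter. Among the compounds with values here, no step between compounds differing in a single place is available, so the size of any single change has not yet been seen directly in this set.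

Compound 4 `Nc1ncc(Cc2ccc(Br)cc2)c(N)n1` has not yet been run. Against compound 3 it carries the change bromo in place of 2-methoxyethoxy on an aromatic carbon: the five-atom chain with its two acceptors leaves and a single bromine enters, on an aromatic carbon of a six-membered aromatic ring of carbon only, para to a group of 9 heavy atoms.

With nothing comparable measured, the step in this assay is expected to be modest; a small rise is the guess, though a result within the scatter of compound 3 would not surprise. Compound 4 is estimated at 3.3 in this assay, with a range of 2.6 to 4, which means an expected step of a number 0.22 log units higher from compound 3 to compound 4 (within the scatter).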

Compound 4, logarithm of the reciprocal of the active concentration, log(1/C): 3.98
For compound 4 the middle estimate is 0.68 log units below the measured one; measured number inside the range.
By their numbers in this assay, from the lowest: compound 1; then compound 3; then compound 2; then compound 4.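

In this assay, the series now has its first step between compounds differing in one place: a number 0.90 log units higher from compound 3 to compound 4 (beyond the scatter), with bromo in place of 2-methoxyethoxy on an aromatic carbon para to a group of 9 heavy atoms. Within the data shown here, the earlier compounds offered no such pair, so this is the first direct sign that the group at this position can shift the read-out beyond the scatter. The chain's 5 heavy atoms and 2 hydrogen-bond acceptors are not needed for activity here, as compound 4 reaches 3.98 with a single bromine and 0 hydrogen-bond acceptors in that place, but nothing measured bears on what lies behind the step.

This one exchange alters the atom type, the size of the group and the acceptor count together, so the step cannot be assigned to any one of them. Open questions are how chloro, methyl, methoxy or an amine on the same aromatic carbon would compare with bromo, and whether a longer chain ending in a carboxylic acid would fall nearer compound 3 or compound 4.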